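The compounds below may be only part of what the source reports. "The series", "measured", "known", "first", "only" and "open" are said of these compounds alone.

Compound 1 `Cc1cc(=O)n(-c2ccccc2C(F)(F)F)nc1C(=O)Nc1ccc(Oc2ncnc3ccsc23)c(F)c1` and compound 2 `Cc1cc(=O)n(-c2ccc(Br)cc2F)nc1C(=O)Nc1ccc(Oc2ncnc3ccsc23)c(F)c1` share one core, and compound 3 `Cc1cc(=O)n(-c2ccccc2C(F)(F)F)nc1C(=O)Nc1ccc(Oc2ncnc3sccc23)cc1` and compound 4 `Cc1cc(=O)n(-c2ccc(Br)cc2F)nc1C(=O)Nc1ccc(Oc2ncnc3sccc23)cc1` share another; how the two cores differ is not broken down here. In a functional assay on HepG2 cells (Homo sapiens) for cytotoxicity, read by MTT assay, with a stated time of 72 h (on this read-out higher numbers stand for weaker inhibition and lower numbers for stronger inhibition), compound 1 gives 9380 nM, and compound 2 gives 3350 nM. The change between them, (4-bromo-2-fluorophenyl in place of 2-(trifluoromethyl)phenyl on an aromatic nitrogen), brought a 2.8-fold lower number from compound 1 to compound 2 (0.45 log units; beyond the scatter).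

For compound 3 the result is a limit of the assay and not a number: in this assay compound 3 gives > 40000 nM. This is the limit of > 40000 nM in this assay, at which 1 of the 3 values shown sits.

Compound 4 carries the same change on the other core, (4-bromo-2-fluorophenyl in place of 2-(trifluoromethyl)phenyl on an aromatic nitrogen). Because compound 1 to compound 2 showed a 2.8-fold lower number from compound 1 to compound 2 (0.45 log units; beyond the scatter), a step of about the same size is expected here, so that the estimate means an at least 1.8-fold lower number from compound 3 to compound 4 (0.25 log units; that floor lies within the scatter). Since compound 3 is known only as a limit, the starting point is uncertain, and the estimate for compound 4 stays broad: in this assay compound 4 is expected to give about 22000 nM, between 8000 nM and 60000 nM, with a fair chance that only a limit is reported.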

Compound 4, half-maximal inhibitory concentration: 6300 nM
Beside the measured number, compound 4's estimate is 3.5-fold (0.54 log units) above it; the measured number lies below the stated range.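

In this assay, putting 4-bromo-2-fluorophenyl in place of 2-(trifluoromethyl)phenyl gave an at least 6.3-fold lower number from compound 3 to compound 4 (0.80 log units; beyond the scatter), so on both cores shown this change moves the number in the same direction, towards stronger inhibition. Whether the step has the same size on both cores stays unsettled, as compound 3 is known only as a limit of the assay and not as a number: the same change on two cores in this assay, a 2.8-fold lower number (0.45 log units; beyond the scatter) from compound 1 to compound 2 and an at least 6.3-fold lower number (0.80 log units; beyond the scatter) from compound 3 to compound 4; the limit leaves it open whether they differ

Two cores with one pair each are a small base, and they do not show that the change would behave this way on any further core.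

The compounds shown leave open whether a plain phenyl or a 4-chlorophenyl on that aromatic nitrogen would follow the same course, and whether the bromine or the fluorine of the new group accounts for the step. Within the data shown here, how the two cores compare with each other also stays open, as no pair here differs only in the core.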